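Amide aryl replacement in the shared series: compound 4

The source may hold more compounds than are shown below. What is called first, only, known or untested is meant among the compounds shown, and "the series" means these compounds.

Measured in a functional assay on HepG2 cells (Homo sapiens) for antiproliferative activity, read by CCK-8 assay, with a stated time of 72 h; on this read-out higher numbers stand for weaker inhibition and lower numbers for stronger inhibition:
compound 1, `COc1ccc(C(=O)Nc2cccc(-c3oc4cc(-c5ccc(F)cc5)ccc4c(=O)c3O)c2)cc1`, gives 8420 nM
compound 2, `Cc1ccccc1C(=O)Nc1cccc(-c2oc3cc(-c4ccc(F)cc4)ccc3c(=O)c2O)c1`, gives 19400 nM
compound 3, `O=C(Nc1cccc(-c2oc3cc(-c4ccc(F)cc4)ccc3c(=O)c2O)c1)c1cc(F)cc(F)c1`, gives 4960 nM

Compound 3 carries the lowest number of the three. Its gap to compound 1, a 1.7-fold lower number from compound 1 to compound 3 (0.23 log units; within the scatter), lies within the scatter, so these two cannot be ordered; only compound 2 stands apart, with a 3.9-fold lower number from compound 2 to compound 3 (0.59 log units; beyond the scatter).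

Compound 4, `O=C(Nc1cccc(-c2oc3cc(-c4ccc(F)cc4)ccc3c(=O)c2O)c1)c1cnc(Cl)nc1Cl`, differs from compound 3 in a single place: 2,4-dichloropyrimidin-5-yl in place of 3,5-difluorophenyl on a carbonyl carbon. All three measured steps exchange the aryl on the same carbonyl carbon. Two of them were modest, a 2.3-fold higher number from compound 1 to compound 2 (0.36 log units; beyond the scatter) and a 3.9-fold lower number from compound 2 to compound 3 (0.59 log units; beyond the scatter); the third, a 1.7-fold lower number from compound 1 to compound 3 (0.23 log units; within the scatter), stayed within the scatter. Within the data shown here, none of these steps introduces a ring with hetero atoms or with hydrogen-bond acceptors, so no measured step covers the present change directly; the measured swaps only show that exchanging this aryl has moved the numbers by modest amounts at most. On that basis a small shift in this assay is expected, with a 1.2-fold higher number from compound 3 to compound 4 (0.08 log units; within the scatter) as the expected step, and the direction left open. Compound 4 is therefore estimated at 6000 nM in this assay, with a range from 2000 nM to 20000 nM.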

Compound 4, half-maximal inhibitory concentration: > 100000 nM
Compound 4 ended at the assay's limit; the forecaster's own chance of this, stated with the estimate: 10%; middle value at least 16-fold (1.22 log units) away from the limit.
By their numbers in this assay, from the lowest: compounds 3 and 1 (each within the scatter of the next); then compound 2. At a limit, above all of these: compound 4.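

In this assay compound 4 stands at a limit of the assay, not at a measured number: the limit of > 100000 nM in this assay, at which 1 of the 4 values shown sits.

As far as these compounds go, every step into compound 4 lies beyond the scatter, and the true size of each remains unknown: an at least 20-fold higher number from compound 3 to compound 4 (1.30 log units; beyond the scatter), an at least 11-fold higher number from compound 1 to compound 4 (1.07 log units; beyond the scatter) and an at least 5.1-fold higher number from compound 2 to compound 4 (0.71 log units; beyond the scatter). The earlier exchanges on this carbonyl carbon suggested a position where the aryl could be varied with modest consequences, but 2,4-dichloropyrimidin-5-yl, the only ring here with hetero atoms and hydrogen-bond acceptors, shows that this tolerance does not extend to every aryl of the same heavy-atom count.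

The ring nitrogens and the chlorines enter together in compound 4, so the compounds shown cannot assign the loss to either one, nor give any reason for it. A dichlorophenyl and an unchlorinated pyrimidine ring on the same carbonyl carbon would separate the two changes, and a compound giving a number short of the limit would also show how steep the loss is.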